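A Nitro Swap on the Phenyl Ring of Compound 2

This account rests on a few compounds, and the source may have more. Where it says the series, first, only, none or still open, it means among the compounds named here.

In a functional assay on K562 cells (Homo sapiens) for antiproliferative activity, read by MTT assay (a higher number here means a weaker inhibitor, a lower number a stronger inhibitor), compound 1 (`O=C(CCCCCNC(=S)N/N=C(\c1ccccc1)c1ccccn1)NO`) gives 2140 nM and compound 2 (`O=C(CCCCCNC(=S)N/N=C(\c1ccccc1)c1ccccc1F)NO`) gives 4630 nM as the higher of the two numbers. Compound 2 is therefore the weaker inhibitor of the measured pair. Compound 3 (`O=C(CCCCCNC(=S)N/N=C(\c1ccccc1)c1ccccc1[N+](=O)[O-])NO`) keeps the rest of compound 2 but has nitro in place of fluoro on an aromatic carbon, ortho to a large group (nitro in place of fluoro on an aromatic carbon). Put another way, 2-fluorophenyl becomes 2-nitrophenyl. Among the measured compounds shown here, only one measured step bears on this change, and it is modest (a 2.2-fold higher number from compound 1 to compound 2 (0.34 log units; beyond the scatter)). That step swapped pyridin-2-yl for 2-fluorophenyl on the same carbon, so it shows what one change of this aromatic group did, but it says nothing about nitro. For the measured compounds named here, no measured compound carries a nitro group, which leaves the direction open. A step of similar or smaller size is expected, quite possibly none beyond the scatter. The estimated step is small (a 1.2-fold lower number from compound 2 to compound 3 (0.06 log units; within the scatter)). In this assay compound 3 is estimated at 4000 nM (expected range 1800 nM to 9000 nM).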

Compound 3, half-maximal inhibitory concentration: 2330 nM
Compound 3: the middle estimate sits 1.7-fold (0.23 log units) above what was measured, within the range that was stated.
By their numbers in this assay, from the lowest: compounds 1, 3 and 2 (each within the scatter of the next, the first and the last beyond it).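

Placing nitro instead of fluoro on this aromatic carbon gives, in this assay, a 2.0-fold lower number from compound 2 to compound 3 (0.30 log units; within the scatter), so the numbers do not separate these two groups at this position even though nitro has more heavy atoms than fluoro. The comparison with the pyridin-2-yl compound adds a second point: 2-nitrophenyl in its place gives a 1.1-fold higher number from compound 1 to compound 3 (0.04 log units; within the scatter), whereas 2-fluorophenyl in that same place gave a 2.2-fold higher number from compound 1 to compound 2 (0.34 log units; beyond the scatter), so a step beyond the scatter is not seen for every substituted phenyl group here. Nothing shown explains why the three numbers fall as they do.

As far as these compounds go, with only fluoro and nitro at this position, it remains open whether an amine or a carboxylic acid on the same aromatic carbon would also stay within the scatter of compound 3. The compounds shown also leave open how a longer chain in the shared core would behave alongside the 2-nitrophenyl group, since that part of the structure is the same in all three.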